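Series notes: cyano in place of tert-butyl, cell tolerance

The source may hold more compounds than are shown below. What is called first, only, known or untested is meant among the compounds shown, and "the series" means these compounds.

Measured so far:
- compound 1 `COc1ccc(C(C)(C)NC(=O)c2ccc([N+](=O)[O-])o2)cc1`: in an ADME assay on Vero cells (Chlorocebus sabaeus) for cytotoxicity, read by MTT assay, with a stated time of 48 h (a higher number here means that more compound is tolerated, a lower number that less compound is tolerated), compound 1 gives 82000 nM
- compound 2 `CC(C)(C)c1ccc(C(C)(C)NC(=O)c2ccc([N+](=O)[O-])o2)cc1`: in this assay compound 2 is known only as a limit of the assay, > 150000 nM

Compound 2 therefore stands at the upper edge of the numbers shown, on (the limit of > 150000 nM in this assay, at which 1 of the 2 values shown sits). Compound 3 `CC(C)(NC(=O)c1ccc([N+](=O)[O-])o1)c1ccc(C#N)cc1` differs from it by cyano in place of tert-butyl on an aromatic carbon. Among the measured compounds shown here, only one measured step bears on the change: an at least 1.8-fold higher number from compound 1 to compound 2 (0.26 log units; that floor lies within the scatter), whose floor lies within the scatter, so it gives no firm direction for swapping one substituent at this position for another. No step beyond the scatter is expected, and an at least 1.3-fold lower number from compound 2 to compound 3 (0.13 log units; that floor lies within the scatter) is the estimated change. For compound 3 the expected value in this assay is 110000 nM, with a range from 40000 nM to 300000 nM.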

Compound 3, half-maximal cytotoxic concentration: 83000 nM
Compound 3: middle estimate off by 1.3-fold (0.12 log units), on the high side; the range from low to high includes it.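

In this assay, among the compounds shown here, cyano and methoxy on this aromatic carbon give no separable difference, the first such comparison at this position: a 1.0-fold higher number from compound 1 to compound 3 (0.01 log units; within the scatter). Replacing tert-butyl with cyano gives an at least 1.8-fold lower number from compound 2 to compound 3 (0.25 log units; that floor lies within the scatter), so only a floor is available for this change. Compound 2 is known only as a limit of the assay, > 150000 nM.

As far as these compounds go, the true distance between tert-butyl and the two smaller groups therefore stays open. So does whether an amine or a carboxylic acid on this carbon would shift tolerance beyond the scatter.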